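The compounds below may be only part of what the source reports. "The series", "measured", "known", "first", "only" and "open" are said of these compounds alone.

Values in a functional assay on PC-3 cells (Homo sapiens) for cytotoxicity, read by MTT assay, with a stated time of 48 h; a higher number here means a weaker inhibitor, a lower number a stronger inhibitor:
- Compound 1 `COc1cc(OC)c(OC)cc1/C=C/C(=O)/C=C/c1cc2ccccc2nc1Cl`: 3120 nM
- Compound 2 `COc1ccc(/C=C/C(=O)/C=C/c2cc3ccccc3nc2Oc2ccccc2)cc1OC`: > 10000 nM (a limit, not a number)
- Compound 3 `COc1cc(OC)c(OC)cc1/C=C/C(=O)/C=C/c1cc2ccccc2nc1Oc1ccccc1`: not yet measured

Compound 2 has no exact value and sits at the limit of > 10000 nM in this assay, at which 1 of the 2 values shown sits. So its true strength in this assay is unknown, and it offers only a loose starting point.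

Compound 3 differs from compound 2 at a single place: methoxy in place of hydrogen on an aromatic carbon. Among the compounds with values here, no measured pair shows what this change does, so any forecast is uncertain. Within the data shown here, the one exact number nearby is that of compound 1, at 3120 nM, and it suggests that a value within the range of the assay is reachable. A modest move towards a stronger inhibitor, meaning a lower number, is therefore expected, though another reading at the limit would be no surprise. The expected step is an at least 1.4-fold lower number from compound 2 to compound 3 (0.15 log units; that floor lies within the scatter). For compound 3 the estimated value is 7000 nM, with an expected range from 2000 nM to 20000 nM.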

Compound 3, half-maximal inhibitory concentration: 7290 nM
Estimate against measurement, compound 3: 1.0-fold (0.02 log units) below; the measured number falls inside the stated range.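

In this assay, methoxy in place of hydrogen on an aromatic carbon, ortho to a large group, gives an at least 1.3-fold lower number from compound 2 to compound 3 (0.13 log units; that floor lies within the scatter), so this position accepts the added group and the phenoxy compounds can reach a readable number. As far as these compounds go, the true size of that step stays unknown, since compound 2 is a limit and not a number: the limit of > 10000 nM in this assay, at which 1 of the 3 values shown sits. Phenoxy in place of chloro on an aromatic carbon gives a 2.3-fold higher number from compound 1 to compound 3 (0.37 log units; beyond the scatter), the first exact comparison here, and the chloro compound holds the lower number.

From the compounds shown here alone, whether a hydroxyl group or an amine on the same aromatic carbon would do more than methoxy remains open. So does whether an amine or a morpholine in place of chloro or phenoxy would give a lower number than either.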